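From 3-chloro-4-fluorophenyl to 3-ethynylphenyl: notes on the series

A few compounds are considered here, and "the series" means these few. Any claim that something is new, unique, unknown or untested is made for them only; others in the source may bear on it.

Of the compounds shown here, three have numbers so far in a functional assay on HeLa cells (Homo sapiens) for antiproliferative activity, read by MTT assay, with a stated time of 48 h; on this read-out higher numbers stand for weaker inhibition and lower numbers for stronger inhibition. Compound 2 (`O=C(/C=C/c1ccccc1)Nc1cc2c(Nc3ccc(F)c(Cl)c3)ncnc2s1`) gives 2140 nM, the lowest of the three and the strongest inhibition measured to date. Compound 1 (`C#Cc1cccc(Nc2ncnc3cc(NC(=O)/C=C/c4ccccc4)sc23)c1`) gives 20500 nM and compound 3 (`COc1ccc(/C=C/C(=O)Nc2cc3c(Nc4cc(Cl)cc(Cl)c4)ncnc3s2)cc1`) gives 43300 nM. Both of these values lie above that of compound 2 by more than the scatter.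

The next compound to consider is compound 4 (`C#Cc1cccc(Nc2ncnc3sc(NC(=O)/C=C/c4ccccc4)cc23)c1`), which differs from compound 2 in one place: 3-ethynylphenyl in place of 3-chloro-4-fluorophenyl on a nitrogen on an aromatic ring. In words, 3-ethynylphenyl stands in place of 3-chloro-4-fluorophenyl on a nitrogen on an aromatic ring.

For the measured compounds named here, no measured pair shows this change alone, so the expectation rests on thin evidence. Compound 1 carries the same 3-ethynylphenyl group and gives 20500 nM, a weaker result than compound 2 shows, but its core is not identical to that of compound 2. It therefore serves only as a loose guide to direction, and the full gap is not expected to carry over.

In this assay the expected change is moderate, a 2.8-fold higher number from compound 2 to compound 4 (0.45 log units; beyond the scatter), toward weaker inhibition and modestly beyond the scatter. The estimate for compound 4 is 6000 nM, with an expected range of 1800 nM to 20000 nM.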

Compound 4, half-maximal inhibitory concentration: 4640 nM
Beside the measured number, compound 4's estimate is 1.3-fold (0.11 log units) above it, and the stated range covers the measured number.
By their numbers in this assay, from the lowest: compound 2; then compound 4; then compound 1; then compound 3.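

In this assay, for the compounds shown here, a 2.2-fold higher number from compound 2 to compound 4 (0.34 log units; beyond the scatter) gives the first reading of this change on its own, with the rest of the structure held constant. On a nitrogen on an aromatic ring, 3-ethynylphenyl thus gives weaker inhibition than 3-chloro-4-fluorophenyl, even though both groups have the same count of heavy atoms and one six-membered aromatic ring of carbon only; the difference lies in chlorine and fluorine leaving and a triple bond entering. Nothing at hand bears on the origin of this step.

As far as these compounds go, this is a single pair in this assay, so it remains open whether the same direction would hold with a different group on the amide side of the shared core, such as a cinnamoyl phenyl ring carrying a dimethylamino group. Also open, from the compounds shown here alone, is how a 3-bromophenyl or a 3-cyanophenyl group would read on the same nitrogen, and so whether chlorine, fluorine or the whole substitution pattern carries the lower number of compound 2.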